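A few compounds are considered here, and "the series" means these few. Any claim that something is new, unique, unknown or untested is made for them only; others in the source may bear on it.

Three compounds share one core and were tested in an assay on THP-1 cells for displacement of a labelled ligand from C-C chemokine receptor type 1 (Homo sapiens); on this read-out higher numbers stand for weaker inhibition and lower numbers for stronger inhibition. Within the data shown here, compound 1 `Cc1ccccc1CCC(=O)N[C@@H](C(=O)N1CCC(c2ccc(Cl)cc2)CC1)C(C)C` gives 19 nM, and compound 2 `CC(C)CCC(=O)N[C@@H](C(=O)N1CCC(c2ccc(Cl)cc2)CC1)C(C)C` gives 26 nM; the step of a 1.4-fold higher number from compound 1 to compound 2 (0.14 log units; within the scatter) is the only single change measured so far. Compound 3 `Cc1ccccc1C(=O)NC(C(=O)N1CCC(c2ccc(Cl)cc2)CC1)C(C)C` gives 36 nM, the highest of the three numbers, yet its gaps to compound 2 and to compound 1 both fall within the scatter, so the three stand together.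

Compound 4 `Cc1ccccc1C(=O)N[C@@H](C(=O)N1CCC(c2ccc(Cl)cc2)CC1)C(C)C` differs from compound 3 only in this: the two compounds have the same atoms and bonds; at least one stereo element is drawn with a configuration in one of them and without one in the other: 1 of 1 stereo elements differ; a stereocentre at a saturated chain carbon is drawn without a configuration in compound 3 and R in compound 4. Among the measured compounds shown here, no measured step concerns such a change, since the one step known swaps one group for another on a chain carbon. What the numbers do show is that compound 1 and compound 2, both drawn with a defined configuration at that carbon, give the lowest numbers of the set, while compound 3 drawn without one gives the highest, all within the scatter. From this a modest step is expected in this assay, if any, toward a lower number, and compound 4 is estimated at 22 nM with a range of 9 nM to 55 nM, meaning an expected step of a 1.6-fold lower number from compound 3 to compound 4 (0.21 log units; within the scatter).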

Compound 4, half-maximal inhibitory concentration: 32 nM
Beside the measured number, compound 4's estimate is 1.5-fold (0.16 log units) below it, and the stated range covers the measured number.
By their numbers in this assay, from the lowest: compounds 1, 2, 4 and 3 (each within the scatter of the next).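

Drawing the chain carbon as R rather than leaving it undefined gives no change that can be told from the scatter in this assay, with a 1.1-fold lower number from compound 3 to compound 4 (0.05 log units; within the scatter). Among these compounds, the only difference behind that step is one of drawing: the fact that one of compounds 3 and 4 is drawn with a defined configuration and the other without, at the place where they differ. With the R configuration now drawn in compound 4, the group on the carbonyl carbon can be compared directly, and neither a 1.2-fold higher number from compound 2 to compound 4 (0.09 log units; within the scatter) nor a 1.7-fold higher number from compound 1 to compound 4 (0.23 log units; within the scatter) lies beyond the scatter, so 2-methylphenyl, isopentyl and 2-(2-methylphenyl)ethyl cannot be told apart at this place.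

The compounds shown leave open how the S configuration at that chain carbon reads in this assay. They also leave open whether an amine or a carboxylic acid on the carbonyl carbon, in place of these groups, would give a step beyond the scatter.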